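The source may report more compounds than this note shows. Statements on the series, on what has been measured and on what is new or still open speak of the compounds shown alone.

Three compounds sharing one core have been compared in an assay on HEK293 cells for inhibition of Steryl-sulfatase (Homo sapiens), tested at 0.1 uM; a higher number here means a stronger effect of the compound at the concentration tested, a lower number a weaker effect. Compound 1 `CCN(Cc1ccccn1)c1cccc(C(=O)N2CCc3ccc(OS(N)(=O)=O)cc3C2)c1` gives 6.5%, compound 2 `CCN(Cc1cccc(Br)c1)c1cccc(C(=O)N2CCc3ccc(OS(N)(=O)=O)cc3C2)c1` gives 20.9%, and compound 3 `CCN(Cc1ccccc1)c1cccc(C(=O)N2CCc3ccc(OS(N)(=O)=O)cc3C2)c1` gives 17.3%. Compound 3 stands second highest of the three: its gap to compound 2 lies within the scatter, while its gap to compound 1 lies beyond it. Compound 4 `CCN(Cc1cccnc1)c1cccc(C(=O)N2CCc3ccc(OS(N)(=O)=O)cc3C2)c1` differs from compound 3 by pyridin-3-yl in place of phenyl on a saturated chain carbon bound to a nitrogen on an aromatic ring. Among the compounds with values here, the steps that bear on this exchange are a number 10.8 percentage points higher from compound 1 to compound 3 (beyond the scatter) and a number 14.4 percentage points higher from compound 1 to compound 2 (beyond the scatter), both showing the aromatic ring with one nitrogen giving the lower number. Compound 4 carries pyridin-3-yl rather than pyridin-2-yl, so the same size is not assured, but a modest fall is expected, a number 8.3 percentage points lower from compound 3 to compound 4 (within the scatter). Compound 4 is therefore estimated at 9%, between 2% and 18%.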

Compound 4, a percentage reported as inhibition, at one concentration (the size of the read-out at that concentration, not a potency): 14.3%
For compound 4 the middle estimate is 5.3 percentage points below the measured one; low and high end bracket the measured number.
By their numbers in this assay, from the lowest: compounds 1, 4, 3 and 2 (each within the scatter of the next, the first and the last beyond it).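

In this assay, pyridin-3-yl in place of phenyl on a saturated chain carbon gives a number 3 percentage points lower from compound 3 to compound 4 (within the scatter), so the clear fall seen with pyridin-2-yl does not carry over to this ring. Against the other two groups the picture is the same, with a number 6.6 percentage points lower from compound 2 to compound 4 (within the scatter) and a number 7.8 percentage points higher from compound 1 to compound 4 (within the scatter), leaving compound 4 inseparable from all three earlier compounds. Nothing available accounts for the difference between the two pyridine rings.

On these data alone, whether pyridin-4-yl would stay within the scatter of compound 3 remains open. So does the effect of a carboxylic acid on that ring.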